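This account rests on a few compounds, and the source may have more. Where it says the series, first, only, none or still open, it means among the compounds named here.

Compound 1 `CC(/C=C/C(=O)NO)=C\c1ccccc1`: 100000000 nM
Compound 2 `CN(O)C(=O)/C=C/C=C/c1ccccc1`: 11800000 nM

In a functional assay on PC-3 cells (Homo sapiens) for inhibition (a lower number here means a stronger inhibitor, a higher number a weaker inhibitor), compound 2 gives 11800000 nM, the lower of the two numbers, and the gap to compound 1 lies beyond the usual scatter. Compound 3 `O=C(/C=C/C=C/c1ccccc1)NO` has not yet been measured. It differs from compound 2 by hydrogen in place of methyl on an amide-type nitrogen. Going by the values given here, no measured pair isolates this change, so the expectation is loose: a moderate move to a lower number, beyond the scatter. The expected change is a 2.4-fold lower number from compound 2 to compound 3 (0.37 log units; beyond the scatter). For compound 3 the estimated value is 5000000 nM, with an expected range of 800000 nM to 40000000 nM.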

Compound 3, half-maximal inhibitory concentration: 173000000 nM
For compound 3 the middle estimate is 35-fold (1.54 log units) below the measured one; the measured number lies above the stated range.
By their numbers in this assay, from the lowest: compound 2; then compounds 1 and 3 (each within the scatter of the next).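

Replacing the methyl with hydrogen on the amide-type nitrogen, whose other neighbours are the carbonyl carbon and an oxygen, gives a much weaker inhibitor in this assay (a 15-fold higher number from compound 2 to compound 3 (1.17 log units; beyond the scatter)). The same swap on the double-bonded chain carbon has no effect that can be told from scatter (a 1.7-fold higher number from compound 1 to compound 3 (0.24 log units; within the scatter)), so in these compounds the methyl matters on the nitrogen only. No measurement here accounts for this difference. From the compounds shown here alone, whether an ethyl group or a longer chain on that nitrogen would give a stronger or weaker inhibitor stays open.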